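Adding Chloro to the Benzyl Group of Compound 2

The source may hold more compounds than are shown below. What is called first, only, known or untested is meant among the compounds shown, and "the series" means these compounds.

Measured compounds:
compound 1, `Nc1ccc(/C=C2\SC(=O)N(Cc3ccccc3)C2=O)cc1`, 42000 nM
compound 2, `C=C(Br)C(=O)Nc1ccc(/C=C2\SC(=O)N(Cc3ccccc3)C2=O)cc1`, 2300 nM
compound 3, `Nc1cccc(/C=C2\SC(=O)N(Cc3ccc(F)cc3)C2=O)c1`, 87000 nM

In a functional assay on CCRF-CEM cells (Homo sapiens) for cytotoxicity, read by cell counting, with a stated time of 3 days (on this read-out higher numbers stand for weaker inhibition and lower numbers for stronger inhibition), compound 2 stands lowest of the three numbers shown, meaning the strongest inhibition. Going by the values given here, the only single-point step among the measured compounds is an 18-fold lower number from compound 1 to compound 2 (1.26 log units; beyond the scatter), which came from placing a (1-bromoethenyl)carbonyl group on the aromatic nitrogen. Among the compounds with values here, compound 3 differs from compound 1 in two places at once, so no step is counted for that pair; in this assay compound 3 gives 87000 nM and compound 1 gives 42000 nM.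

The new compound, compound 4, `C=C(Br)C(=O)Nc1ccc(/C=C2\SC(=O)N(Cc3ccc(Cl)cc3)C2=O)cc1`, keeps everything in compound 2 and changes one thing: chloro in place of hydrogen on an aromatic carbon. The benzyl group thus becomes a 4-chlorobenzyl group, with the chloro sitting para to a large group.

Within the data shown here, no measured step touches the benzyl group; the one large step concerns a different part of the molecule and says nothing about a chloro at this place. With nothing to point either way, the expectation for this assay is a step from compound 2 to compound 4 of about a 1.2-fold lower number from compound 2 to compound 4 (0.06 log units; within the scatter), that is, no change beyond the usual scatter. Compound 4 is therefore estimated at 2000 nM, in a range from 700 nM to 6000 nM.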

Compound 4, half-maximal inhibitory concentration: 2800 nM
For compound 4 the middle estimate is 1.4-fold (0.15 log units) below the measured one; the measured number falls inside the stated range.
By their numbers in this assay, from the lowest: compounds 2 and 4 (each within the scatter of the next); then compound 1; then compound 3.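

In this assay, going by these compounds alone, this is the first step that touches the benzyl group, and placing chloro in hydrogen's stead on its aromatic carbon, para to a large group, gives a 1.2-fold higher number from compound 2 to compound 4 (0.09 log units; within the scatter) and leaves the two compounds level. So this place on the ring accepts one added chlorine atom with no change that can be told from the usual scatter, as long as the (1-bromoethenyl)carbonyl group stays on the aromatic nitrogen, and that group's step remains the only large single change seen among these compounds. No measured information is available that could explain this result.

Still open, as far as these compounds go, is whether a larger or very different group at this same place, such as a methoxy group, an amine or a carboxylic acid, would also leave the number undisturbed, or whether the benzyl group can take only a small addition like chloro. From the compounds shown here alone, it also remains open whether chloro would behave the same way on compound 1, which carries a free amine where compound 2 carries the (1-bromoethenyl)carbonyl group.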